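Swapping 4-fluorophenyl for 4-chlorophenyl

A few compounds are considered here, and "the series" means these few. Any claim that something is new, unique, unknown or untested is made for them only; others in the source may bear on it.

Within the data shown here, in an ADME assay on CCRF-CEM cells (Homo sapiens) for antiproliferative activity, with a stated time of 48 h (on this read-out lower numbers stand for stronger inhibition and higher numbers for weaker inhibition), compound 2 (`C=C(Br)C(=O)Nc1ccc(/C=C/C(=O)c2ccc(F)cc2)cc1`) gives 1100 nM, the lower of the two numbers so far, while compound 1 (`C=C(Br)C(=O)Nc1ccc(/C=C/C(=O)c2ccccc2)cc1`) gives 4000 nM. Compound 3 (`C=C(Br)C(=O)Nc1ccc(/C=C/C(=O)c2ccc(Cl)cc2)cc1`) carries one change from compound 2: chloro in place of fluoro on an aromatic carbon. Among the measured compounds shown here, the only measured step bearing on this is the modest 3.6-fold lower number from compound 1 to compound 2 (0.56 log units; beyond the scatter), which put fluoro in place of hydrogen. It does not compare two halogens, so it offers limited guidance, and no shift beyond the scatter is expected. The expected step is a 1.1-fold lower number from compound 2 to compound 3 (0.04 log units; within the scatter). For compound 3 the estimated value is 1000 nM, with a range of 450 nM to 2300 nM.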

Compound 3, half-maximal inhibitory concentration: 950 nM
For compound 3 the middle estimate is 1.1-fold (0.02 log units) above the measured one; measured number inside the range.
By their numbers in this assay, from the lowest: compounds 3 and 2 (each within the scatter of the next); then compound 1.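

With a 1.2-fold lower number from compound 2 to compound 3 (0.06 log units; within the scatter) for chloro in place of fluoro on this aromatic carbon, this assay does not separate the two halogens. With a 4.2-fold lower number from compound 1 to compound 3 (0.62 log units; beyond the scatter) for chloro in place of hydrogen, chloro joins fluoro as a second halogen whose step from hydrogen lies beyond the scatter. Nothing measured here accounts for either step. From the compounds shown here alone, whether a methoxy group or an amine on this same carbon would give a number like those of compound 2 and compound 3 remains open, as does the effect of a halogen elsewhere on this ring.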